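Hydroxy in Place of Hydrogen on Two Related Cores

The source may report more compounds than this note shows. Statements on the series, on what has been measured and on what is new or still open speak of the compounds shown alone.

In a functional assay on cells (Cancer cell lines, Homo sapiens) for inhibition, with a stated time of 48 h (a lower number here means a stronger inhibitor of growth, a higher number a weaker inhibitor of growth), the measured compounds are:
Compound 1, `COc1cc2c(/C=C3/C(=O)N(C)c4ccccc43)c(Cl)n(C)c2cc1C`: 200 nM
Compound 2, `COc1cc2c(/C=C3/C(=O)N(C)c4ccc(O)cc43)c(Cl)n(C)c2cc1C`: 70 nM
Compound 3, `COc1cc2c(/C=C3/C(=O)N(C)c4ccccc43)c[nH]c2cc1C`: 760 nM

One structural change is made twice. From compound 1 to compound 2 it is hydroxy in place of hydrogen on an aromatic carbon, and it brought a 2.9-fold lower number from compound 1 to compound 2 (0.46 log units; beyond the scatter). From compound 3 to compound 4, which is `COc1cc2c(/C=C3/C(=O)N(C)c4ccc(O)cc43)c[nH]c2cc1C` and not yet measured, it is hydroxy in place of hydrogen on an aromatic carbon. The two place descriptions match word for word, so the change is the same at both sites. The cores of compound 1 and compound 3 differ, and that difference is not broken down here; what the values show is that compound 3 has the highest number of the three, with compound 1 nearest and compound 2 furthest from it. If the hydroxy makes a step of the same size on the core of compound 3, compound 4 is expected to show a 2.8-fold lower number from compound 3 to compound 4 (0.45 log units; beyond the scatter) in this assay. That expectation rests on a single earlier pair and is held loosely. Compound 4 is therefore estimated at 270 nM, with a range from 120 nM to 650 nM.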

Compound 4, concentration for 50% growth inhibition: 2950 nM
Compound 4: the middle estimate sits 11-fold (1.04 log units) below what was measured; measured number above the stated range.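

In this assay, hydroxy in place of hydrogen on an aromatic carbon did not carry over from one core to the other: on the core of compound 3 the step ran the opposite way to the earlier one, with a 3.9-fold higher number from compound 3 to compound 4 (0.59 log units; beyond the scatter). Set side by side, the two steps differ in direction as well as in size: the same change on two cores in this assay, a 2.9-fold lower number (0.46 log units; beyond the scatter) from compound 1 to compound 2 and a 3.9-fold higher number (0.59 log units; beyond the scatter) from compound 3 to compound 4, 11-fold (1.04 log units) apart, beyond the scatter of two such steps. This shows that, among the compounds listed, the result of adding this hydroxy cannot be transferred unchanged between these two cores, but with a single pair on each core it does not show which difference between the cores goes with the reversal, nor which step would be the more typical one.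

The compounds shown carry only hydroxy at this place, and it remains open whether a methoxy group or an amine there would split between the two cores in the same way. Also open, from the compounds shown here alone, is how a hydroxy on another carbon of that ring would behave on either core.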